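The source may hold more compounds than are shown below. What is called first, only, known or untested is meant among the compounds shown, and "the series" means these compounds.

Measured in an ADME assay on HEK293 cells (Homo sapiens) for cytotoxicity, read by reporter gene assay and resazurin assay, with a stated time of 48 h; a lower number here means that less compound is tolerated, a higher number that more compound is tolerated:
- Compound 1 `O=C(Nc1ccccc1)c1cc(Br)cc(Br)c1` gives > 100000 nM (a limit)
- Compound 2 `O=C(Nc1ccc(Sc2nc3ccccc3s2)cc1)c1cc(Br)cc(Br)c1` gives > 100000 nM (a limit)
- Compound 3 `COc1ccccc1C(=O)Nc1ccc(Sc2nc3ccccc3s2)cc1` gives > 100000 nM (a limit)

Compound 3 therefore stands on a limit and not a number, as the limit of > 100000 nM in this assay, at which 3 of the 3 values shown sit, makes clear. Compound 4 `COc1c(Br)cccc1C(=O)Nc1ccc(Sc2nc3ccccc3s2)cc1` is compound 3 with one change, bromo in place of hydrogen on an aromatic carbon in all: bromo in place of hydrogen on an aromatic carbon, ortho to a methoxy group. Going by the values given here, the one measured step, a step that the two limits leave unreadable from compound 2 to compound 3 as it stands, gives no size to carry over. Compound 2 carries bromo groups and reads > 100000 nM as a limit. The expected result is a number no higher from compound 3 to compound 4 (the limit leaves the size open) in this assay and so no step beyond the scatter, with another limit likely. For compound 4 the estimate is 100000 nM with 40000 nM to 200000 nM as its expected range.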

Compound 4, half-maximal cytotoxic concentration: > 100000 nM
Compound 4 was reported as a limit (the forecaster's own chance of this, stated with the estimate: 80%); the middle value lies on the limit itself.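

Compound 2, compound 3 and compound 4 are all reported only as limits, so neither step to compound 4 can be read. The compounds shown leave open what concentration of any of them would reach the half-maximal cytotoxic effect in this assay.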